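A few compounds are considered here, and "the series" means these few. Any claim that something is new, unique, unknown or untested is made for them only; others in the source may bear on it.

Measured so far:

- Compound 1, `ClCc1ccccc1Cn1cnc2c(Cl)nc(Cl)nc21`: 1730 nM
- Compound 2, `ClCc1ccccc1Cn1cnc2c(Cl)ncnc21`: 4570 nM
- Compound 3, `ClCc1ccccc1Cn1cnc2ncnc(Cl)c21`: 3380 nM

All three were tested in a functional assay on NCI-H226 cells (Homo sapiens) for cytotoxicity, read by sulforhodamine B assay, with a stated time of 48 h; on this read-out lower numbers stand for stronger inhibition of growth and higher numbers for weaker inhibition of growth. Compound 1 and compound 2 share one core; compound 3 is built from the same atoms joined differently, and the difference between the two cores is not broken down here.

Within the first core, one change has been measured: chloro in place of hydrogen on an aromatic carbon. This gave a 2.6-fold lower number from compound 2 to compound 1 (0.42 log units; beyond the scatter), a step beyond the usual scatter.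

Compound 4, `ClCc1ccccc1Cn1cnc2nc(Cl)nc(Cl)c21`, has not yet been tested in this assay. It relates to compound 3 as compound 1 relates to compound 2: chloro in place of hydrogen on an aromatic carbon. The words describing where the chlorine enters are the same for both pairs, so this is the same change, made on the second core.

Within the data shown here, with only one earlier example of this change, and that on a different core, the expectation must be held loosely. If the new chlorine acts on compound 3 much as it did from compound 2 to compound 1, compound 4 is expected to give 1400 nM in this assay, a step of a 2.4-fold lower number from compound 3 to compound 4 (0.38 log units; beyond the scatter) from compound 3, because the earlier step was a 2.6-fold lower number from compound 2 to compound 1 (0.42 log units; beyond the scatter). The range expected for compound 4 runs from 600 nM to 3400 nM.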

Compound 4, concentration for 50% growth inhibition: 2130 nM
Compound 4: the middle estimate sits 1.5-fold (0.18 log units) below what was measured; the measured number falls inside the stated range.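

In this assay, chloro in place of hydrogen on the second core gives a 1.6-fold lower number from compound 3 to compound 4 (0.20 log units; within the scatter), so this step taken alone cannot be told apart from the ordinary spread of repeated measurements. Set beside the earlier step, the two cores cannot be told apart either: the same change on two cores in this assay, a 2.6-fold lower number (0.42 log units; beyond the scatter) from compound 2 to compound 1 and a 1.6-fold lower number (0.20 log units; within the scatter) from compound 3 to compound 4, 1.7-fold (0.22 log units) apart, within the scatter of two such steps

This means the data give no sign that the change behaves differently on the two cores, and the direction of the printed numbers is the same in both pairs. Among these compounds, it does not show that the chloro group reliably gives the same gain on both cores, as only the step on the first core stands clear of the scatter and each core offers just one pair.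

The compounds shown carry only chloro or hydrogen on this aromatic carbon between two ring nitrogen atoms, so it remains open how an amine, a methoxy group or a longer chain at that place would compare on either core. Whether the two cores would also respond alike in other cell lines cannot be told from these numbers.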